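Pyrimidinyl piperazine in place of a chlorophenyl piperazine

A few compounds are considered here, and "the series" means these few. Any claim that something is new, unique, unknown or untested is made for them only; others in the source may bear on it.

Measured so far:
compound 1 `CC1(c2ccccc2)CC(=O)N(CC(=O)N2CCOCC2)C1=O`: 300 mg/kg
compound 2 `CC1(c2ccccc2)CC(=O)N(CC(=O)N2CCN(c3ccc(F)cc3)CC2)C1=O`: "not active" (no number reported)
compound 3 `CC1(c2ccccc2)CC(=O)N(CC(=O)N2CCN(c3cccc(Cl)c3)CC2)C1=O`: "not active" (no number reported)

Three compounds share a common core and differ only in the ring amine attached through the amide. In a functional assay on the whole organism (strain CD-1) with Mus musculus as the target, with a stated time of 0.5 h (on this read-out lower numbers stand for an effect already at smaller amounts and higher numbers for an effect only at larger amounts of compound), compound 1 gives 300 mg/kg. Compound 2 is reported in this assay as "not active" (no number reported), with no number attached. Compound 3 stands likewise: in this assay compound 3 is reported as "not active" (no number reported), so no numerical value exists for it, and it cannot be placed on the scale of this assay. Only compound 1 gives a number against which anything can be measured.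

Compound 4 `CC1(c2ccccc2)CC(=O)N(CC(=O)N2CCN(c3ncccn3)CC2)C1=O` has not yet been measured. It differs from compound 3 in one place: pyrimidin-2-yl in place of 3-chlorophenyl on an amine nitrogen in a ring.

For the measured compounds named here, no step between measured compounds exists here, and compound 3 itself has no number, so no size of step can be computed for the change to compound 4. Two of the three measured compounds gave no number at all, and only compound 1 gave a number, which lies at a high dose. On that basis a clear effect at small doses is not expected for compound 4; the most likely outcome is again no number, or a number in the region of compound 1.

Compound 4 is estimated to give 300 mg/kg in this assay, with a range from 100 mg/kg to 1000 mg/kg.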

Compound 4, minimum effective dose: "not active" (no number reported)
No number was reported for compound 4, and the estimate cannot be compared.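

In this assay compound 3 and compound 4 are both reported as "not active" with no number, so no step can be read between them. The compounds shown leave open how far pyrimidin-2-yl and 3-chlorophenyl differ in their effect on this read-out. No evidence at hand bears on this result.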